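A (cyanomethyl)carbonyl group on compound 2

The source may report more compounds than this note shows. Statements on the series, on what has been measured and on what is new or still open speak of the compounds shown alone.

Of the compounds shown here, three sharing one core have been measured in a functional assay on SMMC-7721 cells (Homo sapiens) for inhibition, read by MTT assay; on this read-out higher numbers stand for weaker inhibition and lower numbers for stronger inhibition. Compound 2 (`N#Cc1c(N)sc(C(=O)Nc2ccccc2)c1-c1ccccc1`) gives 5090 nM. Compound 3 (`CCOC(=O)c1c(N)sc(C(=O)Nc2ccccc2)c1-c1ccccc1`) gives 8580 nM, which cannot be told apart from the value of compound 2. Within the data shown here, compound 1 (`N#Cc1c(N)sc(C(=O)Nc2ccc(Cl)cc2)c1-c1ccccc1`) gives 690 nM, the only number of the three clearly lower than that of compound 2.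

The next compound to be tested is compound 4 (`N#CCC(=O)Nc1sc(C(=O)Nc2ccccc2)c(-c2ccccc2)c1C#N`), which carries (cyanomethyl)carbonyl in place of hydrogen on a nitrogen on an aromatic ring. That turns the amino group of compound 2 into ((cyanomethyl)carbonyl)amino.

Neither measured step touches this nitrogen, so both offer only a rough sense of scale. Hydrogen in place of chloro on an aromatic carbon gave a 7.4-fold higher number from compound 1 to compound 2 (0.87 log units; beyond the scatter), a modest step beyond the scatter. Ethoxycarbonyl in place of cyano on an aromatic carbon gave a 1.7-fold higher number from compound 2 to compound 3 (0.23 log units; within the scatter), which stays within the scatter. Among the measured compounds shown here, the data hold no example of a change at the nitrogen, so no direction can be argued with confidence. In this assay, the expected change is a 1.3-fold lower number from compound 2 to compound 4 (0.10 log units; within the scatter), with no shift beyond the scatter anticipated. Compound 4 is estimated at 4000 nM, with an expected range of 800 nM to 20000 nM.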

Compound 4, half-maximal inhibitory concentration: 7930 nM
Beside the measured number, compound 4's estimate is 2.0-fold (0.30 log units) below it, and the stated range covers the measured number.
By their numbers in this assay, from the lowest: compound 1; then compounds 2, 4 and 3 (each within the scatter of the next).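

Among the compounds shown, this is the only change on the nitrogen on the aromatic ring, and in this assay placing (cyanomethyl)carbonyl there in place of hydrogen gives a 1.6-fold higher number from compound 2 to compound 4 (0.19 log units; within the scatter). The position thus takes a group of 5 heavy atoms, with a nitrile and a carbonyl but no ring, without a difference that can be told from the usual scatter, although this rests on a single pair and says nothing about other groups at this nitrogen. Nothing in the material offered accounts for this outcome.

On these data alone, it remains open whether other groups on this nitrogen would also stay within the scatter, such as a plain acetyl group, a benzoyl group, a longer acyl chain ending in a carboxylic acid or an amine, or a simple methyl group. As far as these compounds go, it is equally open whether (cyanomethyl)carbonyl on this nitrogen would give a similarly small step on the chloro-bearing compound 1, which has the lowest number of the series, or on the ethoxycarbonyl-bearing compound 3.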